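From compound 2 to compound 3: notes on one step

The compounds below may be only part of what the source reports. "The series", "measured", "known", "first", "only" and "open" are said of these compounds alone.

Measured so far in a functional assay on NCI-H460 cells (Homo sapiens) for positive allosteric modulation, read by MTT assay, with stated times of 2 h and 72 h, tested at 3 uM; on this read-out lower numbers stand for stronger inhibition and higher numbers for weaker inhibition:
- compound 1 `CCCc1ccc(C(=O)Nc2ccccc2-c2nnn(-c3cccc(OC)c3)n2)cc1` gives 173 nM
- compound 2 `COc1cccc(-n2nnc(-c3ccccc3NC(=O)c3ccc(N)cc3)n2)c1` gives 212 nM

Within the data shown here, compound 2 lies within the scatter of compound 1, the only other measured compound, so the two cannot be ranked. Among the measured compounds shown here, compound 3 `COc1cccc(-n2nnc(-c3ccccc3NC(=O)Nc3ccc([N+](=O)[O-])cc3)n2)c1` carries (4-nitrophenyl)amino in place of 4-aminophenyl on a carbonyl carbon as its single change. For the measured compounds named here, the one measured step of a 1.2-fold higher number from compound 1 to compound 2 (0.09 log units; within the scatter) is a swap on an aromatic carbon, not on a carbonyl carbon, so it bears only loosely on this change and gives no direction. Going by the values given here, no measured step covers this kind of change, so the expectation starts from compound 2 at 212 nM and foresees nothing beyond the scatter, with wide uncertainty. The estimated step is a 1.4-fold higher number from compound 2 to compound 3 (0.15 log units; within the scatter) on present data. Compound 3 is expected at 300 nM within an estimated range of 90 nM to 1000 nM for now.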

Compound 3, half-maximal inhibitory concentration: 190 nM
Estimate against measurement, compound 3: 1.6-fold (0.20 log units) above; low and high end bracket the measured number.
By their numbers in this assay, from the lowest: compounds 1, 3 and 2 (each within the scatter of the next).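

In this assay, (4-nitrophenyl)amino in place of 4-aminophenyl on a carbonyl carbon gives a 1.1-fold lower number from compound 2 to compound 3 (0.05 log units; within the scatter) and, against 4-propylphenyl at the same place, a 1.1-fold higher number from compound 1 to compound 3 (0.04 log units; within the scatter). This carbonyl-side swap, like the earlier swap on an aromatic carbon, therefore stays within the scatter, and the three compounds cannot be ranked. No measurement at hand accounts for this result.

The swap brings in the linking nitrogen and the nitro group together, so these compounds cannot separate the two. Open, from the compounds shown here alone, is how a carboxylic acid or a longer alkyl chain in place of the nitro group would read, and whether any group at this place moves the number beyond the scatter.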